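The source may report more compounds than this note shows. Statements on the series, on what has been measured and on what is new or still open speak of the compounds shown alone.

Measured so far in a functional assay on MDA-MB-231 cells (Homo sapiens) for antiproliferative activity, with a stated time of 48 h; a higher number here means a weaker inhibitor, a lower number a stronger inhibitor:
- compound 1 `CCOC(=O)c1ccc(-c2ccc(N(CC)CC)nn2)cc1` gives 1500 nM
- compound 2 `CCOC(=O)c1ccc(-c2ccc(N(C)C)nn2)cc1` gives > 25000 nM, which is a limit
- compound 3 `COC(=O)c1ccc(-c2ccc(N(C)C)nn2)cc1` gives > 25000 nM, which is a limit

Compound 2 has no number and stands at the limit of > 25000 nM in this assay, at which 2 of the 3 values shown sit. The next compound, compound 4 `CCOC(=O)c1ccc(-c2ccc(OCC)nn2)cc1`, carries ethoxy in place of dimethylamino on an aromatic carbon.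

Among the measured compounds shown here, the one measured step at this position is an at least 16-fold higher number from compound 1 to compound 2 (1.22 log units; beyond the scatter). It is large and beyond the scatter, but it stays among amino groups. The other step, a step that the two limits leave unreadable from compound 2 to compound 3, lies elsewhere on the molecule and does not bear on this change. For the measured compounds named here, no measured step replaces an amino group with ethoxy, so the size of this step is poorly constrained. Compound 1 reads 1500 nM, which shows that a compound with a different group at this position can give a number in this assay. A modest move towards a lower number is therefore expected, and a result at the limit remains quite possible. The expected step is an at least 1.6-fold lower number from compound 2 to compound 4 (0.22 log units; that floor lies within the scatter). For compound 4 the estimate is 15000 nM, with an expected range of 4000 nM to 30000 nM.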

Compound 4, half-maximal inhibitory concentration: > 25000 nM
Compound 4: a limit, no number; the forecaster's own chance of this, stated with the estimate: 45%; at least 1.6-fold (0.22 log units) between middle value and limit.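

In this assay, among the compounds shown here, ethoxy is the first group at this position without an amino nitrogen, and it comes with an at least 16-fold higher number from compound 1 to compound 4 (1.22 log units; beyond the scatter). The reading of compound 4 is a limit, so its step from the dimethylamino compound cannot be read, and ethoxy and dimethylamino cannot be ordered. Of the diethylamino, dimethylamino and ethoxy groups at this position, only diethylamino in compound 1 gives a number, and the series now gathers at one reading: the limit of > 25000 nM in this assay, at which 3 of the 4 values shown sit.

From the compounds shown here alone, it remains open whether a longer chain on the amine, such as dipropylamino, or a cyclic amine such as piperidine, would keep or lower the number seen with diethylamino. Going by these compounds, it is also open how compound 1 would read with a carboxylic acid or an amide in place of its ethyl ester.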